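This account rests on a few compounds, and the source may have more. Where it says the series, first, only, none or still open, it means among the compounds named here.

Compound 1 `O=C1OC(Cc2nc(-c3ccc(Oc4ccccc4)cc3)no2)c2ccccc21`: in a functional assay on RAW264.7 cells (Mus musculus) for inhibition, read by Griess assay, with stated times of 1 h and 24 h (a higher number here means a weaker inhibitor, a lower number a stronger inhibitor), compound 1 gives > 10000 nM, which is a limit of the assay and not a number.
Compound 2 `CCC(C)Oc1ccc(C(O)C2OC(=O)c3c(OC)cc(OC)cc32)cc1`: in this assay compound 2 gives > 10000 nM, again a limit of the assay rather than a number.

Compound 2 therefore stands at the ceiling of what this assay can report, with no numerical value of its own; indeed every measured value in this set sits there (the limit of > 10000 nM in this assay, at which 2 of the 2 values shown sit). Among the compounds with values here, no pair of measured compounds differs in a single place, so no measured step is available to calibrate how large a single change can be here.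

Compound 3 `COc1cc(OC)c2c(c1)C(C(O)c1ccc(OCc3ccc(C#N)cc3)cc1)OC2=O` is the compound still to be measured. It differs from compound 2 in one place: 4-cyanobenzyl in place of sec-butyl on an oxygen on an aromatic ring. Within the data shown here, with both measured compounds at the limit and no measured step to lean on, the step from compound 2 to compound 3 in this assay is expected to be no larger than the usual scatter, in no particular direction, as a step that the limit leaves unreadable from compound 2 to compound 3 expresses. Compound 3 is thus estimated to give about 12000 nM in this assay, with an expected range from 2500 nM to 60000 nM, and a fair chance that only a limit is reported again.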

Compound 3, half-maximal inhibitory concentration: 7360 nM
For compound 3 the middle estimate is 1.6-fold (0.21 log units) above the measured one; measured number inside the range.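

Compound 3 gives the series its first real number, which shows that this oxygen on an aromatic ring can carry a much larger substituent, with a six-membered aromatic ring and a nitrile, and still give a reading inside the range of this assay. Exchanging sec-butyl for 4-cyanobenzyl gives an at least 1.3-fold lower number from compound 2 to compound 3 (0.13 log units; that floor lies within the scatter), so the data support no more than a possible gain, and they do show that the larger group does not push the compound back to the ceiling. The true size of the step stays unknown, since its starting point is only a limit, and that limit still marks most of the set: the limit of > 10000 nM in this assay, at which 2 of the 3 values shown sit.

The compounds shown do not separate the contribution of the nitrile from that of the benzyl ring, which plain benzyl or a 4-methoxybenzyl group at this oxygen could begin to do. Nor do they show how this position responds to a longer straight alkyl chain, or to a chain ending in an amine or a carboxylic acid.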